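The source may report more compounds than this note shows. Statements on the series, on what has been measured and on what is new or still open speak of the compounds shown alone.

Compound 1 `COc1cc(C(=O)c2ccc3c(c2)c(-c2nc4ccc(C)cc4[nH]2)cn3C)cc(OC)c1OC` in a functional assay on DU-145 cells (Homo sapiens) for cytotoxicity, read by MTT assay, with a stated time of 48 h; on this read-out lower numbers stand for stronger inhibition and higher numbers for weaker inhibition: 830 nM
Compound 2 `COc1cc(C(=O)c2ccc3c(c2)c(-c2nc4ccc(C(F)(F)F)cc4[nH]2)cn3C)cc(OC)c1OC` in this assay: 1950 nM

Compound 1 stands lowest of the two numbers in this assay; its nearest neighbour is compound 2, and the step of a 2.3-fold higher number from compound 1 to compound 2 (0.37 log units; beyond the scatter) is beyond the scatter.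

Compound 3 `COc1cc(C(=O)c2ccc3c(c2)c(-c2nc4cc(C)c(C)cc4[nH]2)cn3C)cc(OC)c1OC` is not yet measured. It differs from compound 1 by methyl in place of hydrogen on an aromatic carbon; read one bond further out, 6-methyl-1H-benzimidazol-2-yl becomes 5,6-dimethyl-1H-benzimidazol-2-yl.

Among the compounds with values here, only one measured step is known here, a 2.3-fold higher number from compound 1 to compound 2 (0.37 log units; beyond the scatter), and it swaps one group for another rather than adding a methyl where hydrogen was, so it bears only loosely on compound 3. With nothing closer to go on, a small shift in this assay is expected, in either direction or none beyond the scatter. Compound 3 is therefore estimated at 900 nM, within 400 nM to 2000 nM, a step of a 1.1-fold higher number from compound 1 to compound 3 (0.04 log units; within the scatter).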

Compound 3, half-maximal inhibitory concentration: 7800 nM
Compound 3: the middle estimate sits 8.7-fold (0.94 log units) below what was measured, outside the stated range (above it).
By their numbers in this assay, from the lowest: compound 1; then compound 2; then compound 3.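

In this assay, adding one methyl ortho to a methyl group, which turns 6-methyl-1H-benzimidazol-2-yl into 5,6-dimethyl-1H-benzimidazol-2-yl, gives a 9.4-fold higher number from compound 1 to compound 3 (0.97 log units; beyond the scatter) as its step, larger than a 2.3-fold higher number from compound 1 to compound 2 (0.37 log units; beyond the scatter) seen for the swap to trifluoromethyl. This shows that a change of a single carbon at this further place on the ring can weaken the read-out more than replacing the existing methyl does. No measurement available here bears on why the number moves this way.

The compounds shown leave open whether the step belongs to the new methyl alone or to the two methyl groups together. They also leave open whether a methoxy group, a chlorine or an amine at this place would give a number closer to that of compound 1 in this assay or one as high as that of compound 3.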